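The compounds below may be only part of what the source reports. "The series", "measured", "known", "first", "only" and "open" are said of these compounds alone.

Measured so far in an assay on microsomes from liver for inhibition of sterol O-acyltransferase 1 (Rattus norvegicus); a higher number here means a weaker inhibitor, a lower number a stronger inhibitor:
- compound 1 `CCCCCCCCCCCCn1nnc(C(NC(=O)c2c(C(C)C)cccc2C(C)C)c2ccccc2)n1`: 810 nM
- compound 2 `CCCCCCCCCCCCn1nnc(C(NC(=O)c2c(C)cccc2C)c2ccccc2)n1`: 310 nM
- compound 3 `CCCCCCCCCCCCn1nnc(C(NC(=O)c2ccc(Cl)cc2)c2ccccc2)n1`: 440 nM

Compound 1 gives the highest number of the three. The gap to compound 3 is within the scatter, while the step to compound 2 lies beyond it: a 2.6-fold lower number from compound 1 to compound 2 (0.42 log units; beyond the scatter). Compound 3 sits close to both: a 1.8-fold lower number from compound 1 to compound 3 (0.27 log units; within the scatter) and a 1.4-fold higher number from compound 2 to compound 3 (0.15 log units; within the scatter).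

Compound 4 `CCCCCCCCCCCCn1nnc(C(NC(=O)c2ccnc(SC)c2)c2ccccc2)n1` is not yet measured. It differs from compound 1 at the carbonyl carbon: a group of 8 heavy atoms (6 carbon, 1 nitrogen, 1 sulfur; one six-membered aromatic ring with 1 hetero atom) in place of a group of 12 heavy atoms (12 carbon; one six-membered aromatic ring of carbon only), on a carbonyl carbon

Both measured steps away from compound 1 replace the 2,6-diisopropylphenyl on the carbonyl carbon with a smaller aryl group, and both gave a lower number, one modest and one within the scatter. Within the data shown here, no measured compound carries the entering group, so its own contribution is unknown. The two steps from compound 1 suggest that leaving the 2,6-diisopropylphenyl tends toward a lower number; the expectation for compound 4 is therefore a modest step downward, a 1.6-fold lower number from compound 1 to compound 4 (0.21 log units; within the scatter), with wide uncertainty. The estimate for compound 4 in this assay is 500 nM, range 180 nM to 1500 nM.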

Compound 4, half-maximal inhibitory concentration: 80 nM
Compound 4: middle estimate off by 6.3-fold (0.80 log units), on the high side; measured number below the stated range.
By their numbers in this assay, from the lowest: compound 4; then compounds 2, 3 and 1 (each within the scatter of the next, the first and the last beyond it).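

In this assay, the carbon-only aryl groups on the carbonyl carbon gave numbers spanning a narrow range, whereas the group with a ring nitrogen and a sulfur stands apart from all three: a 10-fold lower number from compound 1 to compound 4 (1.01 log units; beyond the scatter), a 5.5-fold lower number from compound 3 to compound 4 (0.74 log units; beyond the scatter) and a 3.9-fold lower number from compound 2 to compound 4 (0.59 log units; beyond the scatter). The last step is the most telling, since the entering group and the 2,6-dimethylphenyl of compound 2 both have 8 heavy atoms, so heavy-atom count alone does not order this position. Nothing measured here accounts for the gain.

Still open, from the compounds shown here alone, is whether the ring nitrogen or the sulfur-bearing substituent carries the step, which a phenyl ring with the same methylthio group, or a methoxy group in place of methylthio, would separate. Also open, going by these compounds, is whether the step holds with a shorter alkyl chain on the shared core.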